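Hydrazone aryl variation on a shared core: notes

This account rests on a few compounds, and the source may have more. Where it says the series, first, only, none or still open, it means among the compounds named here.

Measured compounds in a functional assay on MKN-45 cells (Homo sapiens) for cytotoxicity, read by MTT assay, with a stated time of 72 h; a lower number here means a stronger inhibitor, a higher number a weaker inhibitor:
Compound 1 `CN(C)CCn1cnnc1-c1cc(Oc2ccc(NC(=O)N/N=C/c3c(O)ccc4ccccc34)cc2F)ccn1` gives 2020 nM.
Compound 2 `CN(C)CCn1cnnc1-c1cc(Oc2ccc(NC(=O)N/N=C/c3ccc(Cl)cc3)cc2F)ccn1` gives 570 nM.
Compound 3 `CN(C)CCn1cnnc1-c1cc(Oc2ccc(NC(=O)N/N=C/c3ccc(O)cc3)cc2F)ccn1` gives 820 nM.

Compound 3 holds the second highest of the three numbers in this assay. Its nearest neighbour is compound 2, and the step of a 1.4-fold higher number from compound 2 to compound 3 (0.16 log units; within the scatter) lies within the scatter, so no order between the two can be claimed. The step of a 2.5-fold lower number from compound 1 to compound 3 (0.39 log units; beyond the scatter) lies beyond the scatter, as does a 3.5-fold lower number from compound 1 to compound 2 (0.55 log units; beyond the scatter); both replace the whole aryl group on the hydrazone carbon.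

Compound 4 `Cc1cc(/C=N/NC(=O)Nc2ccc(Oc3ccnc(-c4nncn4CCN(C)C)c3)c(F)c2)cc(C)c1O` is not yet measured. The change is 4-hydroxy-3,5-dimethylphenyl in place of 4-hydroxyphenyl on a carbon with a double bond to nitrogen. Going by the values given here, no measured step adds substituents to a retained aryl group in this way; the only single-substituent step, a 1.4-fold higher number from compound 2 to compound 3 (0.16 log units; within the scatter), stayed within the scatter, while the larger aryl swaps gave modest steps. The expectation for compound 4 is therefore a step in this assay of no more than the scatter, direction uncertain, expressed as a 1.2-fold lower number from compound 3 to compound 4 (0.07 log units; within the scatter). The estimate for compound 4 is 700 nM, with a range from 280 nM to 1750 nM.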

Compound 4, half-maximal inhibitory concentration: 1510 nM
The estimate for compound 4 lay 2.2-fold (0.33 log units) below the measured number, within the range that was stated.
By their numbers in this assay, from the lowest: compounds 2, 3, 4 and 1 (each within the scatter of the next, the first and the last beyond it).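

In this assay, going by these compounds alone, 4-hydroxy-3,5-dimethylphenyl is the first change that keeps the aryl group and adds to it, and a 1.8-fold higher number from compound 3 to compound 4 (0.27 log units; within the scatter) shows that adding the methyl groups gives no readable shift at this position. The same group does separate from 4-chlorophenyl, with a 2.6-fold higher number from compound 2 to compound 4 (0.42 log units; beyond the scatter), while against 2-hydroxynaphthalen-1-yl the step is a 1.3-fold lower number from compound 1 to compound 4 (0.13 log units; within the scatter), so among the compounds compared with compound 4, only compound 2 is set apart from it. No measurement is available that bears on the origin of these steps.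

The compounds shown leave open how an amine or a carboxylic acid in place of the hydroxy on the phenyl ring would read. Also open, as far as these compounds go, is whether the methyl groups would read the same with chloro in place of that hydroxy.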